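The source may report more compounds than this note shows. Statements on the series, on what has been measured and on what is new or still open speak of the compounds shown alone.

Compound 3 `COc1ccc(-c2nn3cc(-c4cccc(N)c4)nc3s2)cc1OC` gives 13000 nM in a functional assay on FM3A cells (Mus musculus) for inhibition, read by cell counting, with a stated time of 2 days (a higher number here means a weaker inhibitor, a lower number a stronger inhibitor), the higher of the two plain numbers shown, with compound 1 `CCc1ccc(-c2nn3cc(-c4cccc(N)c4)nc3s2)cc1` nearest at 8200 nM, a gap within the scatter. In this assay compound 2 `CCOc1ccc(-c2nn3cc(-c4cccc(N)c4)nc3s2)cc1` gives >= 250000 nM, which is a limit of the assay and not a number. Compound 4 `COc1ccc(-c2nn3cc(-c4cccc(N)c4)nc3s2)cc1` differs from compound 3 by hydrogen in place of methoxy on an aromatic carbon. No measured step removes a methoxy group; the only one-place step shown is an at least 30-fold higher number from compound 1 to compound 2 (1.48 log units; beyond the scatter), which carried compound 2 to the limit of >= 250000 nM in this assay, at which 1 of the 3 values shown sits, when an alkoxy group replaced an alkyl group. Compound 4 keeps an alkoxy group, so a weakening of moderate size, a 3.1-fold higher number from compound 3 to compound 4 (0.49 log units; beyond the scatter), is expected, though with wide uncertainty. Compound 4 is therefore estimated at 40000 nM, between 8000 nM and 250000 nM.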

Compound 4, half-maximal inhibitory concentration: 74000 nM
Compound 4: the middle estimate sits 1.9-fold (0.27 log units) below what was measured; the measured number falls inside the stated range.
By their numbers in this assay, from the lowest: compounds 1 and 3 (each within the scatter of the next); then compound 4. At a limit, above all of these: compound 2.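

Hydrogen in place of the methoxy group ortho to a methoxy group gives a 5.7-fold higher number from compound 3 to compound 4 (0.76 log units; beyond the scatter) in this assay, so this position on the ring counts for the number read. Methoxy in place of ethyl gives a 9.0-fold higher number from compound 1 to compound 4 (0.96 log units; beyond the scatter), so the weakening seen with ethoxy also appears with the smaller alkoxy group. Compound 2 is a limit and not a number, and hydrogen in place of its terminal methyl gives an at least 3.3-fold lower number from compound 2 to compound 4 (0.52 log units; beyond the scatter): the limit of >= 250000 nM in this assay, at which 1 of the 4 values shown sits.

Going by these compounds, whether a hydroxyl group or a fluorine atom at this position would match compound 3 remains open. So does whether a chain longer than ethyl would match compound 1.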